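Halogenated anilide in place of the methyl anilide

The source may report more compounds than this note shows. Statements on the series, on what has been measured and on what is new or still open speak of the compounds shown alone.

Compound 1 `CCOC(=O)C1=Cc2ccccc2OC1(OCc1cn(CC(=O)Nc2ccc(C)cc2)nn1)C(F)(F)F` bears an amide arm that ends in a 4-methylphenyl group. In a functional assay on A549 cells (Homo sapiens) for inhibition, read by MTT assay, with a stated time of 24 h (a higher number here means a weaker inhibitor, a lower number a stronger inhibitor), compound 1 gives 54300 nM. Of the two numbers available this is the higher one; the nearer neighbour is compound 3 `COc1ccc(-c2cc(COC3(C(F)(F)F)Oc4ccccc4C=C3C(=O)O)on2)cc1`, which in this assay gives 36200 nM, and the gap between the two lies within the usual scatter, so no order between compound 1 and compound 3 can be read. Compound 2 `CCOC(=O)C1=Cc2ccccc2OC1(OCc1cc(-c2ccc([N+](=O)[O-])cc2)no1)C(F)(F)F` gives in this assay > 150000 nM, which is a limit of the assay rather than a number (the limit of > 150000 nM in this assay, at which 1 of the 3 values shown sits).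

Compound 4 `CCOC(=O)C1=Cc2ccccc2OC1(OCc1cn(CC(=O)Nc2ccc(I)cc2Cl)nn1)C(F)(F)F` is the variant of compound 1 with 2-chloro-4-iodophenyl in place of 4-methylphenyl on an amide-type nitrogen. For the measured compounds named here, no measured pair shows this change, so its size in this assay cannot be taken from the data at hand. The expected step is a 1.4-fold lower number from compound 1 to compound 4 (0.13 log units; within the scatter), that is, nothing beyond the scatter in either direction. For compound 4 in this assay the estimate is 40000 nM, with a range from 15000 nM to 120000 nM.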

Compound 4, half-maximal inhibitory concentration: 22300 nM
Beside the measured number, compound 4's estimate is 1.8-fold (0.25 log units) above it; the measured number falls inside the stated range.
By their numbers in this assay, from the lowest: compounds 4, 3 and 1 (each within the scatter of the next, the first and the last beyond it). At a limit, above all of these: compound 2.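

Notes on the amide arm: in this assay, 2-chloro-4-iodophenyl in place of 4-methylphenyl on an amide-type nitrogen gives a 2.4-fold lower number from compound 1 to compound 4 (0.39 log units; beyond the scatter), the first step at this position that can be read beyond the scatter. For the compounds shown here, the arm therefore responds to a change in the substituents on its terminal phenyl group, although this one step is modest and shows only that the halogenated group is accepted here with a lower number. No measured property at hand bears on this step.

On these data alone, the change brings in chlorine and iodine together and removes the methyl group, so the part played by each halogen stays open. Whether an anilide carrying chlorine alone or iodine alone, or an amine or carboxylic acid in their place, would move the number also remains unresolved.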